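A shifted fluoro on the aryl group of compound 3

The source may report more compounds than this note shows. Statements on the series, on what has been measured and on what is new or still open speak of the compounds shown alone.

In an ADME assay on microsomes from liver (Mus musculus) for metabolic stability, read by LC-MS (a higher number here means that the compound lasts longer, a lower number that the compound disappears faster), compound 3 `O=C(Nc1ccc(F)c(-c2nc3ncc(-c4cccc(F)c4)cc3[nH]2)c1)N1CCCC1` gives 0.0833 h and stands within the scatter of compound 1 `O=C(Nc1ccc(F)c(-c2nc3ncc(-c4ccc(F)c(F)c4)cc3[nH]2)c1)N1CCCC1` with 0.08 h as its half-life. Compound 2 `O=C(Nc1ccc(F)c(-c2nc3ncc(-c4cccnc4F)cc3[nH]2)c1)N1CCCC1` gives > 1.5 h as a limit of the assay. Compound 4 `O=C(Nc1ccc(F)c(-c2nc3ncc(-c4ccccc4F)cc3[nH]2)c1)N1CCCC1` carries 2-fluorophenyl in place of 3-fluorophenyl on an aromatic carbon of the shared core (2-fluorophenyl in place of 3-fluorophenyl on an aromatic carbon). Among the compounds with values here, two measured steps bear on this. Hydrogen in place of fluoro is a step within the scatter (a 1.0-fold higher number from compound 1 to compound 3 (0.02 log units; within the scatter)), while 3-fluorophenyl in place of 2-fluoropyridin-3-yl is a large one (an at least 18-fold lower number from compound 2 to compound 3 (1.25 log units; beyond the scatter)). Compound 4 keeps a ring of carbon only, as compound 3 does, so the smaller step (a 1.0-fold higher number from compound 1 to compound 3 (0.02 log units; within the scatter)) is the better guide. The expected step (a 1.2-fold higher number from compound 3 to compound 4 (0.08 log units; within the scatter)) stays within the scatter. The estimate for compound 4 is 0.1 h as a middle value, with an expected range from 0.05 h to 0.3 h in half-life.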

Compound 4, half-life: 0.172 h
Beside the measured number, compound 4's estimate is 1.7-fold (0.24 log units) below it, and the stated range covers the measured number.
By their numbers in this assay, from the lowest: compounds 1 and 3 (each within the scatter of the next); then compound 4. At a limit, above all of these: compound 2.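

In this assay, the place of the fluoro on this carbon-only ring matters, whereas losing a fluoro had earlier left the number within the scatter: 2-fluorophenyl in place of 3-fluorophenyl gives a 2.1-fold higher number from compound 3 to compound 4 (0.31 log units; beyond the scatter), and in place of 3,4-difluorophenyl gives a 2.2-fold higher number from compound 1 to compound 4 (0.33 log units; beyond the scatter). Even so, 2-fluorophenyl in place of 2-fluoropyridin-3-yl gives an at least 8.7-fold lower number from compound 2 to compound 4 (0.94 log units; beyond the scatter). That step is only a bound, and compound 2 stands at a limit of the assay: the limit of > 1.5 h in this assay, at which 1 of the 4 values shown sits.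

On these data alone, whether 2-chlorophenyl or 2-methoxyphenyl would follow 2-fluorophenyl at this carbon stays open. So does what pyridin-3-yl without any fluoro would give.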